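Notes on replacing amino with 4-carboxyphenyl

The source may report more compounds than this note shows. Statements on the series, on what has been measured and on what is new or still open speak of the compounds shown alone.

In a functional assay on HCT-116 cells (Homo sapiens) for cytotoxicity, read by sulforhodamine B assay, with a stated time of 24 h (a higher number here means a weaker inhibitor, a lower number a stronger inhibitor), the measured compounds read as follows
- compound 1 `CC(=O)N/N=C1\C(=O)Nc2ccc(S(=O)(=O)N3CCOCC3)cc21` gives 29000 nM
- compound 2 `N/N=C1\C(=O)Nc2ccc(S(=O)(=O)N3CCOCC3)cc21` gives 36300 nM

Among the measured compounds shown here, compound 2 stands level with compound 1, the only other compound measured. For the measured compounds named here, the sole measured step, hydrogen in place of acetyl on an amine nitrogen, is a 1.3-fold higher number from compound 1 to compound 2 (0.10 log units; within the scatter) and stays within the scatter. Compound 3 `O=C1Nc2ccc(S(=O)(=O)N3CCOCC3)cc2/C1=N/c1ccc(C(=O)O)cc1` differs by 4-carboxyphenyl in place of amino on a double-bonded nitrogen with 4-carboxyphenyl in place of amino on a double-bonded nitrogen. That one step says little about so different a group, so no step beyond the scatter is expected in this assay and no direction can be given. The estimated step is a 1.2-fold lower number from compound 2 to compound 3 (0.08 log units; within the scatter) for now. Compound 3 is expected at 30000 nM within an estimated range of 9000 nM to 80000 nM pending measurement.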

Compound 3, half-maximal inhibitory concentration: 23600 nM
Estimate against measurement, compound 3: 1.3-fold (0.10 log units) above, and the stated range covers the measured number.
By their numbers in this assay, from the lowest: compounds 3, 1 and 2 (each within the scatter of the next).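

In this assay the double-bonded nitrogen takes 4-carboxyphenyl, with its 9 heavy atoms and aromatic ring, in place of amino while the number stays within the scatter (a 1.5-fold lower number from compound 2 to compound 3 (0.19 log units; within the scatter)). The same holds against the acetamido group (a 1.2-fold lower number from compound 1 to compound 3 (0.09 log units; within the scatter)), so three quite different groups at this position remain level. Nothing available explains this result.

Going by these compounds, whether a plain phenyl or a methyl ester in place of the carboxylic acid would also stay level remains open. So does whether any group at this nitrogen can move the number beyond the scatter.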